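Bromo Substitution on a Thienopyrrole Core and Cytotoxicity

The compounds below may be only part of what the source reports. "The series", "measured", "known", "first", "only" and "open" are said of these compounds alone.

Compound 1 `CCCNC(=O)C1CCN(C(=O)c2cc3ccsc3n2Cc2ccc(OC)cc2)CC1` is measured in an ADME assay on HEK-293T cells (Homo sapiens) for cytotoxicity, read by luminescence and CellTiter-Glo, with a stated time of 24 h (on this read-out higher numbers stand for lower toxicity in this test and lower numbers for higher toxicity in this test), where compound 1 gives 23400 nM. Compound 2 `CCCNC(=O)[C@@H]1C[C@H]2CCC[C@@H](C1)[C@@H]2NC(=O)c1cc2scnc2n1Cc1ccc(OC)cc1` reaches only a limit of this assay, > 25000 nM. Compound 3 `CCCNC(=O)[C@@H]1C[C@H]2CCC[C@@H](C1)[C@@H]2NC(=O)c1cc2sc(Br)nc2n1Cc1ccc(OC)cc1` likewise reaches only a limit, > 100000 nM. Between them lies a step that the two limits leave unreadable from compound 2 to compound 3, the change being (bromo in place of hydrogen on an aromatic carbon). The difference between the two cores of compound 1 and compound 2 is not broken down here. Compound 4 `CCCNC(=O)C1CCN(C(=O)c2cc3cc(Br)sc3n2Cc2ccc(OC)cc2)CC1` differs from compound 1 by bromo in place of hydrogen on an aromatic carbon; this is the same kind of change as that from compound 2 to compound 3, though there the ring carbon sits next to the ring nitrogen as well as next to the ring sulfur. The step of a 1.1-fold lower number from compound 1 to compound 4 (0.03 log units; within the scatter) is expected to stay small, since compound 2 to compound 3 gave a step that the two limits leave unreadable from compound 2 to compound 3. Compound 4 is therefore estimated at 22000 nM.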

Compound 4, half-maximal cytotoxic concentration: > 100000 nM
Compound 4: a limit, no number; the forecaster's own chance of this, stated with the estimate: 30%; middle value at least 4.5-fold (0.65 log units) away from the limit.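

In this assay, bromo in place of hydrogen on an aromatic carbon gives an at least 4.2-fold higher number from compound 1 to compound 4 (0.63 log units; beyond the scatter), which on the core of compound 1 points to lower toxicity in this test. The same change from compound 2 to compound 3 cannot be read, both values being limits, and that pair neither confirms nor contradicts a transfer of the result between the two cores. Compound 4 itself reaches only a limit, which leaves the full size of the step open: the limit of > 100000 nM in this assay, at which 2 of the 4 values shown sit.

The compounds shown leave open how a chloro, a methyl or an amine in that same place would read in this assay. They also leave open whether any of these would give a number rather than a limit.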